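An Acyl Group Grows From Ethyl to Cyclopentyl

The source may report more compounds than this note shows. Statements on the series, on what has been measured and on what is new or still open speak of the compounds shown alone.

Compound 1 `Cc1[nH]nc(N)c1-c1ccc(Cl)c(Cl)c1`: > 100000 nM in an assay on Sf9 cells for inhibition of mitogen-activated protein kinase kinase kinase 14 (Homo sapiens), read by ADP-Glo, with a stated time of 60 min; on this read-out higher numbers stand for weaker inhibition and lower numbers for stronger inhibition; this is a limit of the assay, not a number.
Compound 2 `Cc1[nH]nc(N)c1-c1ccc(OCc2ccccc2)cc1`: > 100000 nM in this assay; this is a limit of the assay, not a number.
Compound 3 `CCC(=O)n1nc(C)c(-c2ccc(Cl)c(Cl)c2)c1N`: 27400 nM in this assay.

The three measured compounds share a core and differ only in the groups attached to it. Compound 3 is the only one of the three that gives a number in this assay; it carries a propanoyl group on a ring nitrogen. Compound 1 and compound 2 sit at the limit of > 100000 nM in this assay, at which 2 of the 3 values shown sit. Because both sit at a limit, nothing can be said about any order between compound 1 and compound 2.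

Compound 4 `Cc1nn(C(=O)C2CCCC2)c(N)c1-c1ccc(Cl)c(Cl)c1` has not yet been measured. It differs from compound 3 in one place: cyclopentyl in place of ethyl on a carbonyl carbon. Going by the values given here, no measured pair shows this exact change, so the expectation rests on compound 3 alone. The step from compound 3 to compound 4 is expected to be small, a 1.8-fold lower number from compound 3 to compound 4 (0.26 log units; within the scatter), within the scatter or slightly towards stronger inhibition. Compound 4 is therefore expected to give about 15000 nM in this assay, with a range from 5000 nM to 60000 nM.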

Compound 4, half-maximal inhibitory concentration: 41000 nM
The estimate for compound 4 lay 2.7-fold (0.44 log units) below the measured number, within the range that was stated.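

Replacing the ethyl on the carbonyl carbon with cyclopentyl gives a 1.5-fold higher number from compound 3 to compound 4 (0.18 log units; within the scatter), so this assay does not separate these two compounds. Until now, a single compound carrying an acyl group on the aromatic nitrogen had given a number; compound 4 is a second, and it shows that a five-membered carbon ring can take the place of the small ethyl chain without a change beyond the scatter. Compound 1 and compound 2, which have no such acyl group, still give only a limit of the assay, not a number: the limit of > 100000 nM in this assay, at which 2 of the 4 values shown sit.

On these data alone, it remains open whether any group on this carbonyl carbon can give much stronger inhibition. A longer chain, a phenyl ring or a chain ending in an amine could each test this.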